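A few compounds are considered here, and "the series" means these few. Any claim that something is new, unique, unknown or untested is made for them only; others in the source may bear on it.

The compounds here share one core, and the question is how far they damage cells. Compound 1 is `O=c1c(C2=CS(=O)(=O)c3cc(O)ccc3N2)c(O)c2cc(F)ccc2n1Cc1ccc(F)cc1` and compound 2 is `CS(=O)(=O)Nc1ccc2c(c1)S(=O)(=O)C=C(c1c(O)c3cc(F)ccc3n(Cc3ccc(F)c(F)c3)c1=O)N2`. In an ADME assay on 2209-23 cells (Homo sapiens) for cytotoxicity, read by WST assay (on this read-out higher numbers stand for lower toxicity in this test and lower numbers for higher toxicity in this test), compound 1 gives > 50000 nM, which is a limit of the assay rather than a number. In this assay compound 2 likewise gives > 50000 nM, again a limit and not a measured number. Compound 2 therefore stands where every value shown stands, as the limit of > 50000 nM in this assay, at which 2 of the 2 values shown sit, makes plain; nothing measured separates it from compound 1.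

Compound 3 is `CCCC(C)n1c(=O)c(C2=CS(=O)(=O)c3cc(NS(C)(=O)=O)ccc3N2)c(O)c2cc(F)ccc21`. Its difference from compound 2 is 1-methylbutyl in place of 3,4-difluorobenzyl on an aromatic nitrogen, in words 1-methylbutyl in place of 3,4-difluorobenzyl on an aromatic nitrogen. Going by the values given here, no pair of measured compounds shows what such a change does in this assay, so no measured step gives guidance.

For compound 3 no movement beyond the scatter is expected, which is what a number no higher from compound 2 to compound 3 (the limit leaves the size open) means as an expected step. Compound 3 is estimated to give 50000 nM in this assay, with a range from 20000 nM to 120000 nM, and a limit rather than a number is the more likely report.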

Compound 3, half-maximal cytotoxic concentration: > 50000 nM
Compound 3: no number, only a limit; the forecaster's own chance of this, stated with the estimate: 70%; the middle value sits exactly at the limit.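

In this assay, going by these compounds alone, compound 2 and compound 3 both give only a limit and not a number, so no step between them can be read. The compounds shown leave open at what concentration any of them would damage these cells, and whether 1-methylbutyl in place of 3,4-difluorobenzyl changes that concentration at all.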